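Swapping a chain nitrile for a dimethylamide

The source may hold more compounds than are shown below. What is called first, only, known or untested is meant among the compounds shown, and "the series" means these compounds.

Two compounds sharing one core have been measured in an assay on isolated protein for inhibition of leukotriene B4 receptor 1 (Homo sapiens), tested at 10 uM; a higher number here means more inhibition at the concentration tested (going by the name of the read-out), a lower number less inhibition:

- compound 1, `C=CCc1cc(C(C)=O)c(O)cc1OCCCCCCCCCCC#N`; in this assay compound 1 gives 50%
- compound 2, `CCc1cc(C(C)=O)c(O)cc1OCCCCCC(C)(C)C#N`; in this assay compound 2 gives 85%

Going by the values given here, compound 2 stands highest of the two numbers; its only neighbour is compound 1, whose number lies lower by a margin beyond the usual scatter. Among the compounds with values here, no pair of compounds differing in a single place has been measured, so these two values show only that they differ and give no step to lean on.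

Compound 3, `CCc1cc(C(C)=O)c(O)cc1OCCCCCCC(=O)N(C)C`, has not yet been measured in this assay. It differs from compound 2 in one place: (dimethylcarbamoyl)methyl in place of 1-cyano-1-methylethyl on a saturated chain carbon, five bonds along the chain from an oxygen on an aromatic ring. The 1-cyano-1-methylethyl group leaves and a (dimethylcarbamoyl)methyl group enters, on a saturated chain carbon, five bonds along the chain from an oxygen on an aromatic ring.

Without any measured step of this kind, a moderate loss is expected, a step of a number 25 percentage points lower from compound 2 to compound 3 (beyond the scatter). Compound 3 is therefore estimated at 60%, with a range from 30% to 85%.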

Compound 3, a percentage reported as inhibition, at one concentration (the size of the read-out at that concentration, not a potency): 100%
Beside the measured number, compound 3's estimate is 40 percentage points below it; measured number above the stated range.
By their numbers in this assay, from the lowest: compound 1; then compound 2; then compound 3.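

In this assay, going by these compounds alone, replacing 1-cyano-1-methylethyl with (dimethylcarbamoyl)methyl on a saturated chain carbon, five bonds along the chain from an oxygen on an aromatic ring, gives the only single-place step available here: a number 15 percentage points higher from compound 2 to compound 3 (beyond the scatter). This shows that the 1-cyano-1-methylethyl group is not needed at this position for high inhibition at the concentration tested, since the amide-bearing group in compound 3 gives a higher number, something the earlier pair, differing in more than one place, could not show. No measurement is available that accounts for this rise.

The entering and leaving groups differ in several features at once, so the compounds shown do not tell whether the nitrile, the branching or the dimethylamide carbonyl matters, and they leave open how a carboxylic acid, a primary amide or a longer chain ending in the same dimethylamide would read at this position. With only a read-out at one concentration, they also give no potency for compound 3 or compound 2.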